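A Ring Swap on the Oxygen and Expected Tolerability

A few compounds are considered here, and "the series" means these few. Any claim that something is new, unique, unknown or untested is made for them only; others in the source may bear on it.

Three compounds built on one shared core have been compared in an ADME assay on PBMC cells (Homo sapiens) for cytotoxicity; a higher number here means that more compound is tolerated, a lower number that less compound is tolerated. Compound 1 `CCO/N=C(/c1ccc(Br)cc1)C1CCN(C(C)(C)CCNC(=O)c2c(Cl)cncc2Cl)CC1` gives 34000 nM in this assay. Compound 2 `Cc1cccnc1OC(c1ccc(C(F)(F)F)cc1)C1CCN(C(C)CCNC(=O)c2c(Cl)cncc2Cl)CC1` gives 33000 nM in this assay. Compound 3 `CC(CCNC(=O)c1c(Cl)cncc1Cl)N1CCC(C(Oc2cccc(Cl)n2)c2ccc(S(C)(=O)=O)cc2)CC1` is reported in this assay only as a limit, > 29500 nM, and not as a number, which is the limit of > 29500 nM in this assay, at which 1 of the 3 values shown sits.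

Compound 2 thus holds the lowest of the two numbers reported, yet its nearest neighbour, compound 1, sits within the scatter of repeated measurements, so the two cannot be set in any order. For the measured compounds named here, no pair of measured compounds differs in a single place, so no measured step is available to guide the next change.

Compound 4 `CC(CCNC(=O)c1c(Cl)cncc1Cl)N1CCC(C(Oc2ccccc2Cl)c2ccc(C(F)(F)F)cc2)CC1` has not yet been measured in this assay. It differs from compound 2 in one place: 2-chlorophenyl in place of 3-methylpyridin-2-yl on an oxygen on a saturated carbon. With the measured values of compound 1 and compound 2 sitting within the scatter of each other, and the third value a limit, the step of a 1.2-fold lower number from compound 2 to compound 4 (0.09 log units; within the scatter) is expected to stay within the usual scatter in either direction. Compound 4 is therefore estimated at 27000 nM in this assay, with a range from 11000 nM to 55000 nM.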

Compound 4, half-maximal cytotoxic concentration: 4400 nM
Estimate against measurement, compound 4: 6.1-fold (0.79 log units) above; measured number outside the range, below it.
By their numbers in this assay, from the lowest: compound 4; then compounds 2 and 1 (each within the scatter of the next).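

The oxygen on the saturated carbon turns out to be a place where the attached ring counts in this assay: 2-chlorophenyl in place of 3-methylpyridin-2-yl gives a 7.5-fold lower number from compound 2 to compound 4 (0.88 log units; beyond the scatter). This is the only measured step shown and it lies beyond the scatter, whereas the earlier compounds offered two values within the scatter of each other, a limit, and no pair differing in a single place. The change removes the ring nitrogen, with the hydrogen-bond acceptor counted for it, and brings in a chlorine on a ring of carbon only, but nothing measured here says which part of that exchange accounts for the step.

The compounds shown leave open whether the loss of the nitrogen or the arrival of the chlorine carries the step, and a plain phenyl or a 3-methylphenyl on the same oxygen would pull the two apart. Equally open, going by these compounds, is how a ring bearing an amine or a carboxylic acid on this oxygen would read in this assay.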